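The compounds below may be only part of what the source reports. "The series", "measured", "known", "first", "only" and "open" are said of these compounds alone.

Compound 1 `COc1cccc(/C=C/C(=O)c2cc(NC(C)=O)ccc2O)c1` and compound 2 `CC(=O)Nc1ccc(O)c(C(=O)/C=C/c2cccc(F)c2)c1` share one core; compound 3 `COc1ccccc1-c1cc(=O)c2cc(NC(C)=O)ccc2o1` and compound 4 `CC(=O)Nc1ccc2oc(-c3ccccc3F)cc(=O)c2c1` share another. The difference between the two cores is not broken down here. In an ADME assay on THP-1 cells (Homo sapiens) for cytotoxicity, read by flow cytometry and propidium iodide staining, with a stated time of 72 h (a lower number here means a stronger inhibitor, a higher number a weaker inhibitor), compound 1 gives 93700 nM. Compound 2 gives 78600 nM in this assay, and the step between them is a 1.2-fold lower number from compound 1 to compound 2 (0.08 log units; within the scatter), made by fluoro in place of methoxy on an aromatic carbon. Compound 3 gives 50000 nM in this assay, the lowest of the three numbers, though its gaps to compound 2 and to compound 1 both lie within the scatter, so no order among the three is claimed.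

Compound 4 is not yet measured. It differs from compound 3 by fluoro in place of methoxy on an aromatic carbon. This is the same kind of change as that from compound 1 to compound 2, but not the same: there the place was meta to a large group, here it is ortho to a large group. The change occurs twice among these compounds, and its one measured occurrence, on the first core, moved the number only within the scatter. Among the measured compounds shown here, with no second example on the core of compound 3, the expectation for compound 4 rests on that single step. A small step is expected here, a 1.1-fold lower number from compound 3 to compound 4 (0.05 log units; within the scatter), on the strength of a 1.2-fold lower number from compound 1 to compound 2 (0.08 log units; within the scatter). In this assay compound 4 is expected to give 45000 nM, with a range from 20000 nM to 100000 nM.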

Compound 4, half-maximal inhibitory concentration: > 125000 nM
Compound 4: no number, only a limit; the forecaster's own chance of this, stated with the estimate: 20%; at least 2.7-fold (0.44 log units) between middle value and limit.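

In this assay fluoro in place of methoxy on an aromatic carbon gives an at least 2.5-fold higher number from compound 3 to compound 4 (0.39 log units; beyond the scatter) on the core of compound 3, and the step on the core of compound 1 does not carry over to this core: the same change on two cores in this assay, a 1.2-fold lower number (0.08 log units; within the scatter) from compound 1 to compound 2 and an at least 2.5-fold higher number (0.39 log units; beyond the scatter) from compound 3 to compound 4, at least 2.9-fold (0.47 log units) apart, beyond the scatter of two such steps. For compound 4 the reading of > 125000 nM is a limit of the assay and not a number, so its step has a lower bound only: the limit of > 125000 nM in this assay, at which 1 of the 4 values shown sits. The two occurrences differ in core and also in place on the ring, with the fluoro of compound 4 ortho to a large group, so these two pairs do not show which of the two differences separates the steps, and they give no general rule for the change across the series.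

Still open is how far the result depends on fluoro itself, since the compounds shown do not tell whether chloro, methyl or an amine at the same carbon on the core of compound 3 would stay close to compound 3 or also reach the limit. Also open, going by these compounds, is what the same change does on the core of compound 1 when it sits ortho to a large group.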